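A Methyl Added to a Core That Shows No Potency

The source may hold more compounds than are shown below. What is called first, only, known or untested is meant among the compounds shown, and "the series" means these compounds.

Of the compounds shown here, three built on one shared core have been tested in a functional assay on HeLa cells (Homo sapiens) for cytotoxicity, read by MTT assay, with a stated time of 72 h; on this read-out lower numbers stand for stronger inhibition and higher numbers for weaker inhibition. Compound 1 `Cc1cc(C)nc(SCc2cc(=O)c3cc(Cl)ccc3o2)n1` carries a chloro group on the fused benzene ring. In this assay compound 1 gives > 25000 nM, which is a limit of the assay rather than a number. Compound 3 `Cc1cc(C)nc(SCc2cc(=O)c3ccccc3o2)n1` has hydrogen at that position. In this assay compound 3 gives > 25000 nM, again a limit. Compound 2 `Cc1nnc(SCc2cc(=O)c3ccccc3o2)o1` carries a different outer ring. In this assay compound 2 gives > 25000 nM, also a limit.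

Going by the values given here, the only single-point step measured, a step that the two limits leave unreadable from compound 1 to compound 3, cannot be sized because of the limit of > 25000 nM in this assay, at which 3 of the 3 values shown sit. Compound 3 therefore stands exactly where the other two do: at the limit, with no number of its own.

Compound 4 `Cc1ccc2oc(CSc3nc(C)cc(C)n3)cc(=O)c2c1` differs from compound 3 by methyl in place of hydrogen on an aromatic carbon. Among the compounds with values here, no measured step adds a methyl on that ring, so the data give no direction for the change. Since every value shown sits at the limit, compound 4 is expected to do the same, with the step that the limit leaves unreadable from compound 3 to compound 4 from compound 3 to compound 4 being essentially none. The estimate for compound 4 in this assay is 40000 nM, with a range from 12000 nM to 130000 nM.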

Compound 4, half-maximal inhibitory concentration: > 25000 nM
Compound 4 ended at the assay's limit; the forecaster's own chance of this, stated with the estimate: 85%; the middle value lies beyond the limit too.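

Neither the change from compound 3 to compound 4 nor the change from compound 1 to compound 4 can be sized, since each compares one limit with another and no numbers: the limit of > 25000 nM in this assay, at which 4 of the 4 values shown sit.

From the compounds shown here alone, what stays open is how far beyond the limit these compounds lie, and whether any change to the shared core would give a measurable value in this assay.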